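The source may hold more compounds than are shown below. What is called first, only, known or untested is meant among the compounds shown, and "the series" means these compounds.

Measured so far:
compound 1, `CC1CCCN(Cc2c(-c3nnc(SC(C)C)n3-c3ccccc3)n(C)c3ccccc23)C1`, giving 6.03 in a physicochemical assay for lipophilicity; a higher number here means a more lipophilic compound, a lower number a more polar compound
compound 2, `CC1CCCN(Cc2c(-c3nnc(SC(C)C)n3-c3ccccc3)n(C)c3ccc(F)cc23)C1`, giving 6.18 in this assay

Among the measured compounds shown here, compound 1 holds the lower of these two numbers, though the single known step, a number 0.15 log units higher from compound 1 to compound 2 (within the scatter), does not separate the pair. Compound 3, `CC(C)Sc1nnc(-c2c(CNCCN3CCCC3)c3ccccc3n2C)n1-c1ccccc1`, differs from compound 1 in one place: (2-(pyrrolidin-1-yl)ethyl)amino in place of 3-methylpiperidin-1-yl on a saturated chain carbon bound to an aromatic carbon. For the measured compounds named here, that fluoro step concerns an unrelated part of the structure, so no measured step bears on this exchange. The expectation rests on the structural change alone: a downward step, a number 0.93 log units lower from compound 1 to compound 3 (beyond the scatter), is expected. Compound 3 is therefore estimated at 5.1, with a range from 4.5 to 5.7.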

Compound 3, partition coefficient: 4.83
The estimate for compound 3 lay 0.27 log units above the measured number, and the stated range covers the measured number.
By their numbers in this assay, from the lowest: compound 3; then compounds 1 and 2 (each within the scatter of the next).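

At this saturated chain carbon bound to an aromatic carbon, placing (2-(pyrrolidin-1-yl)ethyl)amino in place of 3-methylpiperidin-1-yl gives a number 1.20 log units lower from compound 1 to compound 3 (beyond the scatter) in this assay. This position can therefore carry a change that moves the number well beyond the scatter, which the fluoro step did not show. Nothing available accounts for the size of this step. The exchange alters the ring, the chain and the hydrogen-bond donor count together, and the compounds shown cannot separate these. Going by these compounds, how a simple dimethylamino group or a morpholine ring would read at this carbon stays open.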